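The compounds below may be only part of what the source reports. "The series", "measured", "known", "first", "only" and "open" are said of these compounds alone.

Measured compounds:
Compound 1, `CC(C#Cc1cccc(C(=O)NCCC(c2ccccc2)c2ccc(OC(F)(F)F)cc2)c1)N(O)C(N)=O` — 110 nM in an assay for inhibition of Polyunsaturated fatty acid 5-lipoxygenase (Homo sapiens), read by HPLC, with stated times of 15 min and 10 min; on this read-out higher numbers stand for weaker inhibition and lower numbers for stronger inhibition
Compound 2, `C[C@H](C#Cc1cccc(C(=O)NCCC(c2ccc(F)cc2)c2ccc(C(F)(F)F)cc2)c1)N(O)C(N)=O` — 220 nM in this assay
Compound 3, `C[C@H](C#Cc1cccc(C(=O)NCCC(c2ccc(F)cc2)c2ccc(OC(F)(F)F)cc2)c1)N(O)C(N)=O` — 260 nM in this assay

Compound 1 has the lowest number of the three. Compound 2 stands within the scatter of it, while compound 3 lies beyond the scatter, though only just. Among the measured compounds shown here, the single step between compounds differing in one place, a 1.2-fold higher number from compound 2 to compound 3 (0.07 log units; within the scatter), swaps trifluoromethyl for trifluoromethoxy on the aromatic carbon and leaves the number essentially where it was.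

Compound 4, `CC(C#Cc1cccc(C(=O)NCCC(c2ccccc2)c2ccc(C(F)(F)F)cc2)c1)N(O)C(N)=O`, differs from compound 1 by the reverse of that swap: trifluoromethyl in place of trifluoromethoxy on an aromatic carbon. For the measured compounds named here, the one measured step that bears on this change is the step from compound 2 to compound 3, and it was too small to count. The same exchange in the opposite direction is therefore expected to give no step beyond the scatter in this assay. If anything, the estimate assumes a slightly lower number for compound 4 than for compound 1.

Compound 4 is estimated at 95 nM, with a range from 40 nM to 250 nM, which corresponds to an expected 1.2-fold lower number from compound 1 to compound 4 (0.06 log units; within the scatter).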

Compound 4, half-maximal inhibitory concentration: 150 nM
Compound 4: the middle estimate sits 1.6-fold (0.20 log units) below what was measured; low and high end bracket the measured number.
By their numbers in this assay, from the lowest: compounds 1, 4, 2 and 3 (each within the scatter of the next, the first and the last beyond it).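

With a 1.4-fold higher number from compound 1 to compound 4 (0.13 log units; within the scatter), the exchange of 4-(trifluoromethoxy)phenyl for 4-(trifluoromethyl)phenyl has now been read on a second core in this assay, and there too it stays within the scatter. Among the compounds shown here, the earlier compounds offered only one pair for this change, so its small size could have belonged to that core alone, whereas this place, on an aromatic carbon para to a large group, now gives the same reading in two settings. The two readings also agree with each other, so on the compounds shown this assay does not tell the two groups apart: the same change on two cores in this assay, a 1.2-fold higher number (0.07 log units; within the scatter) from compound 2 to compound 3 and a 1.4-fold lower number (0.13 log units; within the scatter) from compound 4 to compound 1, 1.6-fold (0.21 log units) apart, within the scatter of two such steps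

On these data alone, what remains open is how far this place accepts anything other than these two fluorinated groups, which a chlorine, a methoxy group, a nitrile, an amine or a carboxylic acid in the same place would begin to test. Equally open is what the ring fluorine and the defined stereocentre of compound 2 and compound 3 each contribute, as these two features change together in the compounds shown.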